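Ring opening on the chain of compound 1

The source may hold more compounds than are shown below. What is called first, only, known or untested is meant among the compounds shown, and "the series" means these compounds.

In a functional assay on NCI-H460 cells (Homo sapiens) for inhibition, read by MTT assay, with a stated time of 24 h, tested at 1 ug/mL (on this read-out higher numbers stand for more inhibition of growth at the one concentration tested and lower numbers for less inhibition of growth), compound 1 `O=C(CCCCC1CCSS1)Nc1ccccc1Cl` gives 10.1% and compound 2 `O=C(CCCCC1CCSS1)Nc1ccc(OC(F)(F)F)cc1` gives 12.2% so the two stand within the scatter of each other. Compound 3 `O=C(CCCCC(S)CCS)Nc1ccccc1Cl` is not yet measured. It differs from compound 1 by a single change (a group of 5 heavy atoms (3 carbon, 2 sulfur; no ring) in place of a group of 5 heavy atoms (3 carbon, 2 sulfur; one five-membered non-aromatic ring with 2 hetero atoms), on a saturated chain carbon, four bonds along the chain from a carbonyl carbon) in which the ring gives way to 1,3-disulfanylpropyl. Within the data shown here, no measured pair shows this kind of change, so the expected step of a number 3.9 percentage points higher from compound 1 to compound 3 (within the scatter) is small, slightly upward and within the scatter of this assay at most. For compound 3 the estimated value is 14% with an expected range from 4% to 32% as the working figures.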

Compound 3, percent growth inhibition at one concentration: 8.19%
Beside the measured number, compound 3's estimate is 5.8 percentage points above it; measured number inside the range.
By their numbers in this assay, from the lowest: compounds 3, 1 and 2 (each within the scatter of the next).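

In this assay, the ring giving way to 1,3-disulfanylpropyl gives a number 1.9 percentage points lower from compound 1 to compound 3 (within the scatter). At this place, on a saturated chain carbon, four bonds along the chain from a carbonyl carbon, keeping the ring closed or opening it therefore makes no readable difference, even though the entering group carries hydrogen-bond donors and the leaving group none. No measurement available here explains this result.

Still open, going by these compounds, is whether a carboxylic acid at this chain carbon, or a longer chain carrying the ring, would move the number beyond the scatter.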